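The compounds below may be only part of what the source reports. "The series", "measured", "known", "first", "only" and "open" are said of these compounds alone.

Of the compounds shown here, two from this series have been measured in a functional assay on PC-3 cells (Homo sapiens) for inhibition, read by sulforhodamine B assay, with a stated time of 48 h; a lower number here means a stronger inhibitor, a higher number a weaker inhibitor. Compound 1, `O=c1c(C(=S)Nc2ccccc2)coc2cc(Cl)ccc12`, gives 90800 nM in this assay. Compound 2, `O=c1c(C2N=C(c3ccccc3)SS2)coc2cc(Cl)c(Cl)cc12`, gives 60000 nM in this assay. On these two numbers compound 2 has the lower value, but the gap to compound 1 lies within the scatter of repeated measurements, so nothing can be read into the order of the two.

Compound 3, `O=c1c(C2N=C(c3ccccc3)SS2)coc2cc(Cl)c(F)cc12`, has not been measured yet. Compound 3 differs from compound 2 in one place: fluoro in place of chloro on an aromatic carbon. The change is a fluoro in place of a chloro on an aromatic carbon, and nothing else in the structure moves.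

Among the measured compounds shown here, no measured pair shows what this swap does in this assay, so the expectation can rest only on the size of the change, which is a single halogen atom exchanged for another. The step from compound 2 to compound 3 is expected to be small, a 1.2-fold higher number from compound 2 to compound 3 (0.07 log units; within the scatter), and not beyond the scatter in either direction. For compound 3 the estimate in this assay is 70000 nM, with a likely range from 25000 nM to 200000 nM.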

Compound 3, half-maximal inhibitory concentration: 56900 nM
Beside the measured number, compound 3's estimate is 1.2-fold (0.09 log units) above it; the measured number falls inside the stated range.
By their numbers in this assay, from the lowest: compounds 3, 2 and 1 (each within the scatter of the next).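

Among the compounds shown here, the exchange of chloro for fluoro on this aromatic carbon, ortho to a chloro group, gives a 1.1-fold lower number from compound 2 to compound 3 (0.02 log units; within the scatter) in this assay and so provides the first direct reading of a change at this position. Compound 1 could not provide such a reading, since it differs from compound 2 in more than one place. For this one pair, then, exchanging one single-atom halogen for the other leaves the two numbers within the scatter of each other, though one pair cannot show how other groups would behave here. No independent measurement is available to explain this result.

The compounds shown leave open whether a substituent other than a halogen on this same aromatic carbon, such as an amine, a methoxy group or a nitrile, would produce a step beyond the scatter. They also leave open what would follow from replacing the chloro group retained in both compounds with a bromo group, or from replacing the phenyl group shared by compound 2 and compound 3 with a pyridine ring.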